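The compounds below may be only part of what the source reports. "The series", "measured", "known", "first", "only" and "open" are said of these compounds alone.

Measured compounds in an assay (Rattus norvegicus) for inhibition of Fatty-acid amide hydrolase 1 (Homo sapiens); a lower number here means a stronger inhibitor, a higher number a weaker inhibitor:
compound 1 `COc1ccccc1-c1cnc(C(=O)CCCCCCc2ccccc2)o1` gives 400 nM
compound 2 `O=C(CCCCCCc1ccccc1)c1ncc(-c2cccc(O)c2)o1` gives 50 nM
compound 3 `O=C(CCCCCCc1ccccc1)c1ncc(-c2ccc(F)cc2)o1` gives 62 nM

Compound 3 stands second highest of the three numbers in this assay. Its nearest neighbour is compound 2, and the gap between them, a 1.2-fold higher number from compound 2 to compound 3 (0.09 log units; within the scatter), is within the scatter; the gap to compound 1, a 6.5-fold lower number from compound 1 to compound 3 (0.81 log units; beyond the scatter), is beyond it.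

Compound 4 `O=C(CCCCCCc1ccccc1)c1ncc(-c2ccc(O)cc2)o1` differs from compound 3 by hydroxy in place of fluoro on an aromatic carbon. Among the measured compounds shown here, no measured step exchanges fluoro for hydroxy at the same place, so the bearing steps are indirect. an 8.0-fold lower number from compound 1 to compound 2 (0.90 log units; beyond the scatter) and a 6.5-fold lower number from compound 1 to compound 3 (0.81 log units; beyond the scatter) show that a hydroxy-bearing phenyl and a fluoro-bearing phenyl, each replacing the same 2-methoxyphenyl, land close together, and a 1.2-fold higher number from compound 2 to compound 3 (0.09 log units; within the scatter) confirms that the two are within the scatter of one another. A hydroxy in place of fluoro is therefore expected to move the number little in this assay, and not clearly beyond the scatter in either direction. The expected step is a 1.1-fold lower number from compound 3 to compound 4 (0.05 log units; within the scatter). Compound 4 is estimated at 55 nM, with a range from 20 nM to 150 nM.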

Compound 4, inhibition constant: 140 nM
Beside the measured number, compound 4's estimate is 2.5-fold (0.41 log units) below it; measured number inside the range.
By their numbers in this assay, from the lowest: compounds 2 and 3 (each within the scatter of the next); then compound 4; then compound 1.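

In this assay, the direct exchange of fluoro for hydroxy on an aromatic carbon para to a large group is a modest loss beyond the scatter (a 2.3-fold higher number from compound 3 to compound 4 (0.35 log units; beyond the scatter)), so the closeness of compound 2 and compound 3 does not carry over to a hydroxy and a fluoro at the same place. The place of the hydroxy on the phenyl matters in this series, since 4-hydroxyphenyl in place of 3-hydroxyphenyl also raises the number beyond the scatter (a 2.8-fold higher number from compound 2 to compound 4 (0.45 log units; beyond the scatter)), by a step of about the same size as the exchange of fluoro for hydroxy. 4-Hydroxyphenyl still gives a lower number than 2-methoxyphenyl (a 2.9-fold lower number from compound 1 to compound 4 (0.46 log units; beyond the scatter)), though no measurement at hand bears on the reason for any of these steps.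

Fluoro is shown at one place on the phenyl only, so it stays open whether its number depends on place as the number for hydroxy does. Going by these compounds, it also stays open how an amine or a carboxylic acid in place of the hydroxy on that aromatic carbon would compare with compound 3 and compound 4.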